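A few compounds are considered here, and "the series" means these few. Any claim that something is new, unique, unknown or untested is made for them only; others in the source may bear on it.

Measured so far:
compound 1 `COC(=O)Cc1c(C)n(Cc2ccc(-c3cn(CCCCCC(=O)NO)nn3)cc2)c2ccc(OC)cc12` — 672 nM
compound 2 `COc1ccc2c(c1)c(CC(=O)O)c(C)n2Cc1ccc(-c2cn(CCCCCCC(=O)NO)nn2)cc1` — 116 nM

Among the compounds with values here, in an assay on isolated protein for inhibition of histone deacetylase 8 (Homo sapiens), with a stated time of 2.5 h (a lower number here means a stronger inhibitor, a higher number a weaker inhibitor), compound 1 gives the highest of the two numbers; compound 2 sits well below it, a gap beyond the scatter, but compound 2 differs from compound 1 in more than one place, so the two values alone carry no single attributable step.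

Compound 3 `COC(=O)Cc1c(C)n(Cc2ccc(-c3cn(CCCCCCCC(=O)NO)nn3)cc2)c2ccc(OC)cc12` is not yet measured. It differs from compound 1 by 2-(hydroxycarbamoyl)ethyl in place of hydroxycarbamoyl on a saturated chain carbon, five bonds along the chain from an aromatic nitrogen. With only compound 2 as a guide, a moderate move toward a lower number is expected, a 1.9-fold lower number from compound 1 to compound 3 (0.28 log units; within the scatter), though the direction is uncertain. Compound 3 is estimated at 350 nM, within 120 nM to 1000 nM.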

Compound 3, half-maximal inhibitory concentration: 394 nM
Estimate against measurement, compound 3: 1.1-fold (0.05 log units) below, and the stated range covers the measured number.
By their numbers in this assay, from the lowest: compound 2; then compounds 3 and 1 (each within the scatter of the next).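

In this assay, 2-(hydroxycarbamoyl)ethyl in place of hydroxycarbamoyl on a saturated chain carbon, five bonds along the chain from an aromatic nitrogen, gives a 1.7-fold lower number from compound 1 to compound 3 (0.23 log units; within the scatter). Within the data shown here, this is the first step between compounds that differ in one place. On this core, the chain can therefore carry this extension without a shift beyond the scatter. No measurement on hand bears on this result.

Open, as far as these compounds go, is whether a longer chain ending in hydroxycarbamoyl, or an amine in place of hydroxycarbamoyl, would shift the number beyond the scatter. Compound 2 differs from compound 3 in more than one place and cannot settle this.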